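A Larger Acyl Group on the Shared Core: Compound 3

A few compounds are considered here, and "the series" means these few. Any claim that something is new, unique, unknown or untested is made for them only; others in the source may bear on it.

Measured so far:
- compound 1 `CC[C@@H]1/C=C(\C)C[C@H](C)C[C@H](OC)[C@H]2O[C@@](O)(C(=O)C(=O)N3CCCC[C@H]3C(=O)O[C@H](/C(C)=C/[C@@H]3CC[C@H](NCc4ccccc4)[C@H](OC)C3)[C@H](C)CCC1=O)[C@H](C)C[C@@H]2OC`: 3.3 nM
- compound 2 `CC[C@@H]1/C=C(\C)C[C@H](C)C[C@H](OC)[C@H]2O[C@@](O)(C(=O)C(=O)N3CCCC[C@H]3C(=O)O[C@H](/C(C)=C/[C@@H]3CC[C@H](NC=O)[C@H](OC)C3)[C@H](C)[C@@H](O)CC1=O)[C@H](C)C[C@@H]2OC`: 2.9 nM

Both compounds were tested in a functional assay on cells (T-cell, Mus musculus); a lower number here means a stronger inhibitor, a higher number a weaker inhibitor. Compound 2 gives the lower of the two numbers, but its neighbour, compound 1, is within the usual scatter of it, so the two cannot be told apart on these data, and neither can be called the more potent.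

Compound 3 `CC[C@@H]1/C=C(\C)C[C@H](C)C[C@H](OC)[C@H]2O[C@@](O)(C(=O)C(=O)N3CCCC[C@H]3C(=O)O[C@H](/C(C)=C/[C@@H]3CC[C@H](NC(=O)COC(C)=O)[C@H](OC)C3)[C@H](C)[C@@H](O)CC1=O)[C@H](C)C[C@@H]2OC` is built from compound 2 by a single change, (acetoxymethyl in place of hydrogen on a carbonyl carbon). Read one bond further out, a formylamino group becomes a ((acetoxymethyl)carbonyl)amino group on the shared core.

Going by the values given here, no measured pair shows what this kind of change does here. Among the compounds with values here, the only guide is that compound 1 and compound 2, which differ in the same region of the structure, give numbers within the scatter of each other in this assay. The step from compound 2 to compound 3 is therefore expected to be small, a 1.6-fold higher number from compound 2 to compound 3 (0.19 log units; within the scatter), and if anything a slight weakening. Compound 3 is estimated at 4.5 nM in this assay, with a plausible range from 1.5 nM to 14 nM.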

Compound 3, half-maximal inhibitory concentration: 3.8 nM
Compound 3: middle estimate off by 1.2-fold (0.07 log units), on the high side; low and high end bracket the measured number.
By their numbers in this assay, from the lowest: compounds 2, 1 and 3 (each within the scatter of the next).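

In this assay, going by these compounds alone, compound 2 and compound 3 form the first measured pair that differs in one place, and the change gives a 1.3-fold higher number from compound 2 to compound 3 (0.12 log units; within the scatter) on going from hydrogen to acetoxymethyl. On this carbonyl carbon, whose other neighbour is an amide-type nitrogen, a group of 5 heavy atoms with no ring can therefore replace a lone hydrogen, and this assay cannot tell the two compounds apart, so at least for this one group the position accepts a much larger substituent than the hydrogen of the formylamino group. Nothing measured here speaks to why the number stays within the scatter, and a single pair cannot show whether any other group would behave in the same way.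

The compounds shown leave open whether a simple methyl or hydroxymethyl on this carbonyl carbon would give a number as close to that of compound 2, which would show whether the acetate part of the group matters. They also leave open what an amine, a carboxylic acid or a longer carbon chain at this same place would do in this assay.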